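The source may report more compounds than this note shows. Statements on the series, on what has been measured and on what is new or still open speak of the compounds shown alone.

Three compounds share one core and have been run through a functional assay on HCT-116 cells (Homo sapiens) for inhibition, read by sulforhodamine B assay, with a stated time of 48 h, tested at 50 uM; on this read-out lower numbers stand for less inhibition of growth and higher numbers for more inhibition of growth at the one concentration tested. Compound 2, with the structure `COc1cc(/C=C/C(=O)/C=C/c2cc(OC)c(OC)c(OC)c2)ccc1OCc1cn(CCCOc2cc(=O)oc3ccccc23)nn1`, gives 76%. Compound 3, the structure `COc1cccc(/C=C/C(=O)/C=C/c2ccc(OCc3cn(CCOc4cc(=O)oc5ccccc45)nn3)c(OC)c2)c1`, gives 70%, and compound 1, the structure `COc1ccccc1/C=C/C(=O)/C=C/c1ccc(OCc2cn(CCCCCOc3cc(=O)oc4ccccc34)nn2)c(OC)c1`, gives 33%. Among these three numbers compound 2 stands highest; its gap to compound 3 lies within the usual scatter, so no order between compound 2 and compound 3 can be read, whereas its gap to compound 1 lies beyond the scatter. Compound 4, the structure `COc1cc(/C=C/C(=O)/C=C/c2cccs2)ccc1OCc1cn(CCCOc2cc(=O)oc3ccccc23)nn1`, has not yet been measured in this assay. Its structure differs from that of compound 2 at one place: thiophen-2-yl in place of 3,4,5-trimethoxyphenyl on a double-bonded chain carbon bound to a double-bonded chain carbon. Within the data shown here, no pair of measured compounds isolates this change, and the two compounds that differ from compound 2 elsewhere, compound 1 and compound 3, differ in more than one place at once, so their numbers do not settle the question. The account therefore expects a moderate step downward from compound 2 to compound 4, estimated as a number 21 percentage points lower from compound 2 to compound 4 (beyond the scatter), with wide uncertainty. For compound 4 the expected value in this assay is 55%, lying between 25% and 80%.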

Compound 4, percent growth inhibition at one concentration: 58%
Beside the measured number, compound 4's estimate is 3 percentage points below it; the range from low to high includes it.
By their numbers in this assay, from the lowest: compound 1; then compound 4; then compounds 3 and 2 (each within the scatter of the next).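

In this assay, among these compounds, thiophen-2-yl in place of 3,4,5-trimethoxyphenyl on a double-bonded chain carbon bound to a double-bonded chain carbon gives a number 18 percentage points lower from compound 2 to compound 4 (beyond the scatter), so this place, on which the earlier compounds could not speak alone, does bear on the read-out. The change does not abolish the effect, since compound 4 still gives 58% at the one concentration tested. Nothing at hand accounts for the size of this step.

The compounds shown leave open whether the step follows from the change of ring or from the loss of the three methoxy groups, a question that an unsubstituted phenyl or a furan-2-yl at this place would address. Going by these compounds, whether the step holds with a different chain on the triazole nitrogen also remains open.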